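Ester Chain Extension on a Naphthoquinone Cytotoxicity Scaffold

The source may report more compounds than this note shows. Statements on the series, on what has been measured and on what is new or still open speak of the compounds shown alone.

Measured so far:
- compound 1 `CC(C)=CC[C@H](OC(=O)C=C(C)C)C1=CC(=O)c2c(O)ccc(O)c2C1=O`: 320 nM
- compound 2 `COc1ccc(O)c2c1C(=O)C=C([C@H](CC=C(C)C)OC(C)=O)C2=O`: 590 nM

Of the compounds shown here, two have been tested in an ADME assay on Vero cells (Chlorocebus sabaeus) for cytotoxicity, read by MTT assay, with a stated time of 48 h; on this read-out lower numbers stand for stronger inhibition and higher numbers for weaker inhibition. Compound 1 gives 320 nM in this assay, and compound 2 gives 590 nM. Compound 2 holds the higher of the two numbers, but its gap to compound 1 lies within the scatter, so the two cannot be told apart on these data.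

Compound 3 `COc1ccc(O)c2c1C(=O)C=C([C@H](CC=C(C)C)OC(=O)C=C(C)C)C2=O` has not yet been measured. It differs from compound 2 in one place: 2-methylprop-1-en-1-yl in place of methyl on a carbonyl carbon. The acetyl of compound 2 becomes a (2-methylprop-1-en-1-yl)carbonyl, so the ester now carries the same chain that compound 1 bears.

Among the compounds with values here, no step between measured compounds is available, so the expectation rests on compound 1 and compound 2 alone, whose values sit within the scatter of each other. The step from compound 2 to compound 3 is therefore expected to be small, a 1.3-fold lower number from compound 2 to compound 3 (0.12 log units; within the scatter), with no clear direction beyond the scatter. Compound 3 is estimated at 450 nM, within a range of 200 nM to 1000 nM.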

Compound 3, half-maximal inhibitory concentration: 790 nM
Compound 3: the middle estimate sits 1.8-fold (0.24 log units) below what was measured, within the range that was stated.
By their numbers in this assay, from the lowest: compounds 1, 2 and 3 (each within the scatter of the next, the first and the last beyond it).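

In this assay, replacing the methyl of the acetyl with 2-methylprop-1-en-1-yl on the carbonyl carbon gives a 1.3-fold higher number from compound 2 to compound 3 (0.13 log units; within the scatter), so the read-out does not separate the short ester from the longer one when the aromatic oxygen carries a methyl. The other single change, methyl in place of hydrogen on an oxygen on an aromatic ring with the ester chain held the same, gives a 2.5-fold higher number from compound 1 to compound 3 (0.39 log units; beyond the scatter), a modest step and the only one of the two that lies beyond the scatter. Nothing available explains why either step has the size it does.

The compounds shown leave open whether a longer saturated chain, a phenyl ring or an amine on the same carbonyl carbon would give a step beyond the scatter, or whether the ester could be replaced by an amide. They also leave open whether an ethyl group on that aromatic oxygen would give a step like the one seen with methyl, and whether the ester change would read differently on the core with the free hydroxyl.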